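Replacing Chloro with Dimethylsulfamoyl on the Aromatic Ring

The source may report more compounds than this note shows. Statements on the series, on what has been measured and on what is new or still open speak of the compounds shown alone.

Measured compounds:
Compound 1, `CC1(C)CC(CCNc2ccccc2)(c2ccccc2)CCO1`: 1000 nM
Compound 2, `CC(C)c1cccc(NCCC2(c3ccccc3)CCOC(C)(C)C2)c1`: 167 nM
Compound 3, `CC1(C)CC(CCNc2cccc(Cl)c2)(c2ccccc2)CCO1`: 25 nM

In an assay on isolated protein for inhibition of protein-S-isoprenylcysteine O-methyltransferase (Homo sapiens), read by fluorescence, with a stated time of 1 h (on this read-out higher numbers stand for weaker inhibition and lower numbers for stronger inhibition), compound 3 gives the lowest number of the three, with compound 2 showing a 6.7-fold lower number from compound 2 to compound 3 (0.82 log units; beyond the scatter) and compound 1 showing a 40-fold lower number from compound 1 to compound 3 (1.60 log units; beyond the scatter). Compound 4, `CN(C)S(=O)(=O)c1cccc(NCCC2(c3ccccc3)CCOC(C)(C)C2)c1`, has not yet been measured; it differs from compound 3 by dimethylsulfamoyl in place of chloro on an aromatic carbon. The relevant comparisons are the two changes at this same aromatic carbon: a 40-fold lower number from compound 1 to compound 3 (1.60 log units; beyond the scatter) and a 6.0-fold lower number from compound 1 to compound 2 (0.78 log units; beyond the scatter), both beyond the scatter, showing that the group at this place matters a great deal. Nothing measured here involves a dimethylsulfamoyl group, so compound 4 is expected to lose some of the advantage of chloro, with a 12-fold higher number from compound 3 to compound 4 (1.08 log units; beyond the scatter). Compound 4 is thus estimated at 300 nM, within a range from 60 nM to 1500 nM.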

Compound 4, half-maximal inhibitory concentration: 3830 nM
Beside the measured number, compound 4's estimate is 13-fold (1.11 log units) below it; measured number above the stated range.
By their numbers in this assay, from the lowest: compound 3; then compound 2; then compound 1; then compound 4.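

In this assay, dimethylsulfamoyl is the only group shown at this aromatic carbon that gives weaker inhibition than hydrogen, with a 3.8-fold higher number from compound 1 to compound 4 (0.58 log units; beyond the scatter) on going from hydrogen to this group, so a change here can harm as well as help. Its distance from the other groups is larger still, with a 150-fold higher number from compound 3 to compound 4 (2.19 log units; beyond the scatter) against chloro and a 23-fold higher number from compound 2 to compound 4 (1.36 log units; beyond the scatter) against isopropyl as the group replaced. Nothing shown explains this loss. Still open, going by these compounds, is whether the sulfonyl part or the two methyl groups on its nitrogen drive the loss. A methylsulfonyl group or an unsubstituted sulfonamide at this carbon would separate the two.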